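This account rests on a few compounds, and the source may have more. Where it says the series, first, only, none or still open, it means among the compounds named here.

Within the data shown here, compound 1, `Cc1cc(/C=C/C(=O)O)cc(C)c1Oc1ccc([N+](=O)[O-])c(Nc2ccc(C#N)cc2)n1`, is the first of three measured compounds. In an ADME assay on TZM cells (Homo sapiens) for cytotoxicity, read by XTT assay, with a stated time of 4 days (a lower number here means that less compound is tolerated, a higher number that more compound is tolerated), compound 1 gives 27800 nM. Compound 3, `Cc1cc(/C=C/C(=O)O)cc(C)c1Oc1ccc(N)c(Nc2ccc(C#N)cc2)n1`, shares its core and differs from it only by the change (amino in place of nitro on an aromatic carbon). In this assay compound 3 gives 18000 nM; the step of a 1.5-fold lower number from compound 1 to compound 3 (0.19 log units; within the scatter) is within the scatter, so the two values do not separate.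

Compound 2, `CC(=O)/C=C/c1cc(C)c(Oc2cc(Nc3ccc(C#N)cc3)c([N+](=O)[O-])cc2[N+](=O)[O-])c(C)c1`, is built on a different core; how the core of compound 2 differs from the core of compound 1 is not broken down here. In this assay compound 2 gives 24400 nM, which is within the scatter of both compound 1 and compound 3.

Compound 4, `CC(=O)/C=C/c1cc(C)c(Oc2cc(Nc3ccc(C#N)cc3)c(N)cc2[N+](=O)[O-])c(C)c1`, has not been measured. It differs from compound 2 by the change (amino in place of nitro on an aromatic carbon). This is the same kind of change as that from compound 1 to compound 3, but not the same: in compound 3 the place is on a six-membered aromatic ring with one nitrogen, two atoms from the ring nitrogen, whereas in compound 4 it is on a six-membered aromatic ring of carbon only, meta to a nitro group.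

Because the step of a 1.5-fold lower number from compound 1 to compound 3 (0.19 log units; within the scatter) stayed within the scatter, the step from compound 2 to compound 4 is expected to be of a similar size, a 1.4-fold lower number from compound 2 to compound 4 (0.16 log units; within the scatter). Compound 4 is therefore estimated to give about 17000 nM in this assay, most likely between 8000 nM and 36000 nM.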

Compound 4, half-maximal cytotoxic concentration: 5880 nM
Beside the measured number, compound 4's estimate is 2.9-fold (0.46 log units) above it; measured number outside the range, below it.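

Replacing nitro with amino on an aromatic carbon does not carry from one core to the other at a fixed size in this assay, where a 4.1-fold lower number from compound 2 to compound 4 (0.62 log units; beyond the scatter) is a modest step. Set beside the earlier step, the two results differ: the same change on two cores in this assay, a 1.5-fold lower number (0.19 log units; within the scatter) from compound 1 to compound 3 and a 4.1-fold lower number (0.62 log units; beyond the scatter) from compound 2 to compound 4, 2.7-fold (0.43 log units) apart, beyond the scatter of two such steps. This shows that the step measured on the core of compound 1 did not give the size of the step on the core of compound 2, but it does not show which feature of the cores sets the difference, and it rests on a single pair of compounds for each core, with the differences between those cores not broken down here.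

The compounds shown leave open whether the larger step belongs to the six-membered aromatic ring of carbon only, to the nitro group that remains meta to the new amino group, or to the chain, which could be tested with a carboxylic acid in place of the methyl ketone on the core of compound 2. They also leave open whether a hydroxyl or a methoxy group in the same place would follow the amino group or take a different course on either core.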